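The compounds below may be only part of what the source reports. "The series", "measured", "known", "first", "only" and "open" are said of these compounds alone.

Measured so far:
compound 1 `COc1ccc([C@@H]2[C@@H](Oc3ccccc3)C(=O)N2c2cc(OC)c(OC)c(OC)c2)cc1`, 6900 nM
compound 2 `COc1ccc([C@@H]2[C@H](Oc3ccccc3)C(=O)N2c2cc(OC)c(OC)c(OC)c2)cc1[N+](=O)[O-]`, 69000 nM
compound 3 `COc1cc(N2C(=O)[C@@H](Oc3ccccc3)[C@H]2c2cccc([N+](=O)[O-])c2)cc(OC)c1OC`, 30000 nM

In a functional assay on MCF7 cells (Homo sapiens) for antiproliferative activity, read by MTT assay, with stated times of 24 h and 72 h (a lower number here means a stronger inhibitor, a higher number a weaker inhibitor), compound 3 stands second highest of the three numbers. Its nearest neighbour is compound 2, with a 2.3-fold lower number from compound 2 to compound 3 (0.36 log units; beyond the scatter). Among the compounds with values here, compound 1 lies furthest, its value being lower than that of compound 3, but the two differ in more than one place and no single step joins them. Compound 4 `COc1cc(N2C(=O)[C@@H](Oc3ccccc3)[C@H]2c2ccc(N)cc2)cc(OC)c1OC` differs from compound 3 by 4-aminophenyl in place of 3-nitrophenyl on a saturated ring carbon. Within the data shown here, no measured step involves this change. The one step shown, a 2.3-fold lower number from compound 2 to compound 3 (0.36 log units; beyond the scatter), concerns the aromatic carbon bearing methoxy and is only modest. Without a precedent, a step of little more than the scatter is expected, leaning slightly lower, as a 1.7-fold lower number from compound 3 to compound 4 (0.22 log units; within the scatter). Compound 4 is expected at 18000 nM, within 6000 nM to 55000 nM.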

Compound 4, half-maximal inhibitory concentration: 160000 nM
Compound 4: middle estimate off by 8.9-fold (0.95 log units), on the low side, outside the stated range (above it).
By their numbers in this assay, from the lowest: compound 1; then compound 3; then compound 2; then compound 4.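

In this assay, within the data shown here, the aryl group on the saturated ring carbon is the first site where a change moves the number upward from both nitro compounds. Replacing 3-nitrophenyl with 4-aminophenyl gives a 5.3-fold higher number from compound 3 to compound 4 (0.73 log units; beyond the scatter) and replacing 4-methoxy-3-nitrophenyl with 4-aminophenyl gives a 2.3-fold higher number from compound 2 to compound 4 (0.37 log units; beyond the scatter), with both steps beyond the scatter and in the same direction.

Going by these compounds, whether the amine or its place on the phenyl ring carries these steps stays open, and a plain phenyl or an acetamide-bearing phenyl group would help separate the two. Nothing measured here bears on the cause of these steps.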